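The compounds below may be only part of what the source reports. "The series", "measured", "known", "first", "only" and "open" are said of these compounds alone.

In an ADME assay on WEHI13 cells (Mus musculus) for cytotoxicity, read by MTT assay, with a stated time of 72 h (on this read-out lower numbers stand for higher toxicity in this test and higher numbers for lower toxicity in this test), compound 1 `CCN(CC)Cc1cc(-c2ccc(Cl)cc2)n(Nc2ccnc3cc(Cl)ccc23)c1C` gives 1450 nM and compound 2 `Cc1c(CN2CCCC2)cc(-c2ccc(Cl)cc2)n1Nc1ccnc2cc(Cl)ccc12` gives 2060 nM. Compound 2 holds the highest number of the two; the step of a 1.4-fold higher number from compound 1 to compound 2 (0.15 log units; within the scatter) lies within the scatter. Compound 3 `Cc1c(CN2CCCC2)cc(-c2ccc(C(F)(F)F)cc2)n1Nc1ccnc2cc(Cl)ccc12` differs from compound 2 by trifluoromethyl in place of chloro on an aromatic carbon. Among the measured compounds shown here, no measured step touches this change, since the only step seen alters the amine on the saturated chain carbon, not the six-membered ring of carbon only. With nothing to anchor a direction, compound 3 is expected to stay near compound 2, with a step of a 1.0-fold lower number from compound 2 to compound 3 (0.01 log units; within the scatter) inside the scatter. The estimate for compound 3 in this assay is 2000 nM, within 700 nM to 6000 nM.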

Compound 3, half-maximal cytotoxic concentration: 2680 nM
Compound 3: the middle estimate sits 1.3-fold (0.13 log units) below what was measured; the measured number falls inside the stated range.
By their numbers in this assay, from the lowest: compounds 1, 2 and 3 (each within the scatter of the next).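

In this assay the exchange of 4-chlorophenyl for 4-(trifluoromethyl)phenyl gives a 1.3-fold higher number from compound 2 to compound 3 (0.11 log units; within the scatter) and thus stays within the scatter. The earlier step concerned only the amine, so this is the first reading at this aromatic carbon: among these two groups, the cytotoxicity read-out does not separate chloro from trifluoromethyl. No supporting measurement bears on this result. The compounds shown leave open whether a carboxylic acid or an amine on this aromatic carbon would carry the number beyond the scatter. Going by these compounds, a longer chain in place of the pyrrolidin-1-yl group remains equally open.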